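From Methyl to Bromo: Expected Oral Exposure in Rats

The source may report more compounds than this note shows. Statements on the series, on what has been measured and on what is new or still open speak of the compounds shown alone.

In an ADME assay on the whole organism (strain Sprague-Dawley) for pharmacokinetics, with Rattus norvegicus as the target, at a dose of 5 mg/kg by the oral route (a higher number here means that a larger share of the oral dose reaches the circulation, a lower number that a smaller share of the oral dose reaches the circulation), compound 1 `CC(C)c1ccc2c(Nc3cc(C(=O)N[C@@H](C)c4ccccc4)ccc3Sc3ccc(N)cc3)ncnc2n1` gives 42.4%. Compound 2 `CC(C)c1ccc2c(Nc3cc(C(=O)N[C@@](C)(CO)c4ccccc4)ccc3Sc3ccc(N)cc3)ncnc2n1` gives 13.3%, and compound 3 `Cc1ccc([C@H](C)NC(=O)c2ccc(Sc3ccc(N)cc3)c(Nc3ncnc4nc(C(C)C)ccc34)c2)cc1` gives 12.2%, the lowest of the three numbers. The step of a number 30.2 percentage points lower from compound 1 to compound 3 (beyond the scatter) lies beyond the scatter, whereas the step of a number 1.1 percentage points lower from compound 2 to compound 3 (within the scatter) lies within it. Compound 4 `CC(C)c1ccc2c(Nc3cc(C(=O)N[C@@H](C)c4ccc(Br)cc4)ccc3Sc3ccc(N)cc3)ncnc2n1` differs from compound 3 by bromo in place of methyl on an aromatic carbon, on an aromatic carbon of a six-membered aromatic ring of carbon only, para to a large group. For the measured compounds named here, no measured step exchanges one such group for another; the only measured change on that ring, a number 30.2 percentage points lower from compound 1 to compound 3 (beyond the scatter), puts methyl in place of hydrogen rather than replacing methyl. Going by the values given here, with no matching precedent, the step is expected to stay within the scatter, a number 1.8 percentage points higher from compound 3 to compound 4 (within the scatter). Compound 4 is therefore estimated at 14%, between 5% and 30%.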

Compound 4, oral bioavailability: 24.9%
Beside the measured number, compound 4's estimate is 10.9 percentage points below it, within the range that was stated.
By their numbers in this assay, from the lowest: compounds 3 and 2 (each within the scatter of the next); then compound 4; then compound 1.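

In this assay, the group on this ring carbon matters beyond simply being present, since bromo in place of methyl raises the oral share (a number 12.7 percentage points higher from compound 3 to compound 4 (beyond the scatter)). Bromo still falls short of the bare ring with hydrogen (a number 17.5 percentage points lower from compound 1 to compound 4 (beyond the scatter)), yet it stands clear of the hydroxymethyl compound (a number 11.6 percentage points higher from compound 2 to compound 4 (beyond the scatter)). Nothing measured here explains the difference between bromo and methyl. From the compounds shown here alone, whether chloro, an amine or a carboxylic acid at this place would behave like bromo or like methyl stays open. So does whether any group here can match hydrogen.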